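Swapping a triazole for a hydroxamic acid on the sulfur chain

A few compounds are considered here, and "the series" means these few. Any claim that something is new, unique, unknown or untested is made for them only; others in the source may bear on it.

Measured so far:
Compound 1, `N#Cc1c(N)nc(SCn2cncn2)c(C#N)c1-c1ccc(OCC2CC2)cc1`, gives 1% in an assay on CHO cells for displacement of a labelled ligand from adenosine receptor A3 (Homo sapiens), read by scintillation counting, with a stated time of 120 min, tested at 1 uM; a higher number here means more inhibition at the concentration tested (going by the name of the read-out), a lower number less inhibition.
Compound 2, `N#Cc1c(N)nc2sc(C(N)=O)c(N)c2c1-c1ccc(OCC2CC2)cc1`, gives 13% in this assay.

Compound 1 has the lowest of the two numbers; compound 2 sits higher by a gap beyond the usual scatter. Compound 3, `N#Cc1c(N)nc(SCC(=O)NO)c(C#N)c1-c1ccc(OCC2CC2)cc1`, differs from compound 1 by one change: hydroxycarbamoyl in place of 1H-1,2,4-triazol-1-yl on a saturated chain carbon bound to a sulfur. Going by the values given here, no step between measured compounds involves this change, so the data give no direction to lean on. Because compound 1 gives 1%, the expected step of a number 5 percentage points higher from compound 1 to compound 3 (within the scatter) is small and hardly beyond the scatter. Compound 3 is estimated at 6%, within -5% to 22%.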

Compound 3, a percentage reported as inhibition, at one concentration (the size of the read-out at that concentration, not a potency): 31%
Compound 3: middle estimate off by 25 percentage points, on the low side, outside the stated range (above it).
By their numbers in this assay, from the lowest: compound 1; then compound 2; then compound 3.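

Hydroxycarbamoyl in place of 1H-1,2,4-triazol-1-yl on a saturated chain carbon bound to a sulfur gives a number 30 percentage points higher from compound 1 to compound 3 (beyond the scatter) in this assay and so shows that the group carried here can change the reading. Compounds 1 and 2 could not show this, as they differ in more than one place. No measurement shown gives a reason for this step.

The compounds shown leave open how far this reading depends on hydroxycarbamoyl itself. A carboxylic acid on the same carbon, or a longer chain carrying hydroxycarbamoyl, could read higher or lower.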